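A few compounds are considered here, and "the series" means these few. Any claim that something is new, unique, unknown or untested is made for them only; others in the source may bear on it.

Compound 3 `CC(=O)Nc1cc(/C=C/c2ccccc2)nc2ccccc12` is measured in an ADME assay on J774 cells (Mus musculus) for cytotoxicity, read by MTT assay, with a stated time of 48 h; a higher number here means a weaker inhibitor, a lower number a stronger inhibitor. In this assay compound 3 gives > 25000 nM, which is a limit of the assay rather than a number. Compound 2 `CC(=O)N(C(C)=O)c1cc(/C=C/c2ccccc2)nc2ccccc12` in this assay likewise gives > 25000 nM, again a limit. Compound 1 `NCCNc1cc(/C=C/c2ccccc2)nc2ccccc12` is the only one of the three with a number, and in this assay compound 1 gives 4600 nM. Two of the three values shown thus sit at the limit of > 25000 nM in this assay, at which 2 of the 3 values shown sit. The measured steps are an at least 5.4-fold higher number from compound 1 to compound 2 (0.73 log units; beyond the scatter) and an at least 5.4-fold higher number from compound 1 to compound 3 (0.73 log units; beyond the scatter), while a step that the two limits leave unreadable from compound 2 to compound 3 cannot be read from the two limits.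

The unmeasured compound 4 `C(=C/c1cc(-c2c[nH]c3ccccc23)c2ccccc2n1)\c1ccccc1` differs from compound 3 in one place: 1H-indol-3-yl in place of acetamido on an aromatic carbon. Within the data shown here, none of the measured steps exchanges the group on this aromatic carbon for an aromatic ring, so they do not bear directly on this change; they show only that compound 3 starts from a limit, which leaves room for a lower number but none for a higher one to be read. Compound 4 is therefore expected to show an at least 2.0-fold lower number from compound 3 to compound 4 (0.31 log units; beyond the scatter). The value of compound 4 in this assay is estimated at 12000 nM, between 3000 nM and 25000 nM.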

Compound 4, half-maximal inhibitory concentration: 4100 nM
The estimate for compound 4 lay 2.9-fold (0.47 log units) above the measured number; low and high end bracket the measured number.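

In this assay, an aromatic ring on the carbon opposite the ring nitrogen brings the reading back from the limit: the change gives an at least 6.0-fold lower number from compound 3 to compound 4 (0.78 log units; beyond the scatter), and replacing diacetylamino gives an at least 6.0-fold lower number from compound 2 to compound 4 (0.78 log units; beyond the scatter). Among these compounds, both steps start from a limit, not a number, so their full size stays unknown: the limit of > 25000 nM in this assay, at which 2 of the 4 values shown sit. Against the (2-aminoethyl)amino group, the change gives a 1.1-fold lower number from compound 1 to compound 4 (0.05 log units; within the scatter), which shows that a measurable number at this carbon does not require the 2-aminoethyl chain, as the earlier compounds alone might have suggested.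

The compounds shown leave open whether this reading depends on the whole 1H-indol-3-yl group or on its hydrogen on nitrogen. They also leave open how a phenyl ring, a 1-methyl-1H-indol-3-yl group or a longer aminoalkyl chain would read on this carbon.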